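Opening the chain into a ring on the shared core

The source may hold more compounds than are shown below. What is called first, only, known or untested is meant among the compounds shown, and "the series" means these compounds.

In a functional assay on L1210 cells (Mus musculus) for inhibition (on this read-out higher numbers stand for weaker inhibition and lower numbers for stronger inhibition), compound 1 `Nc1ncnc2c1ncn2C/C=C/CCl` gives 45000 nM and compound 2 `Nc1ncnc2c1ncn2CC#CCO` gives 490000 nM as the higher of the two numbers, which places compound 2 on the side of weaker inhibition. Going by the values given here, the one measured step is an 11-fold higher number from compound 1 to compound 2 (1.04 log units; beyond the scatter) and it is large. That step places 3-hydroxyprop-1-yn-1-yl where 3-chloroprop-1-en-1-yl stood on a saturated chain carbon bound to an aromatic nitrogen.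

Compound 3 `Nc1ncnc2c1ncn2C1C=CCO1` has the same atoms as compound 2 joined differently, and the change is a group of 5 heavy atoms (4 carbon, 1 oxygen; one five-membered non-aromatic ring with 1 hetero atom) in place of a group of 5 heavy atoms (4 carbon, 1 oxygen; no ring), on an aromatic nitrogen on an aromatic nitrogen. Among the compounds with values here, neither measured compound has a ring in this group, so the single step gives only a loose guide. It shows that a change in this group can move the number well beyond the scatter, but it does not fix a direction for closing a ring.

With compound 2 at the top of the two numbers, a move down is judged somewhat more likely. The expected step is a 2.5-fold lower number from compound 2 to compound 3 (0.39 log units; beyond the scatter) and it remains a loose estimate. Compound 3 is expected at 200000 nM in this assay with an estimated range from 50000 nM to 700000 nM for the coming measurement.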

Compound 3, half-maximal inhibitory concentration: > 500000 nM
Compound 3 ended at the assay's limit; the forecaster's own chance of this, stated with the estimate: 15%; middle value at least 2.5-fold (0.39 log units) from the limit.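

Compound 3 reads as a limit of the assay and not as a number in this assay: the limit of > 500000 nM in this assay, at which 1 of the 3 values shown sits.

Closing the 4-hydroxybut-2-yn-1-yl chain into the five-membered non-aromatic ring on the aromatic nitrogen gives an at least 1.0-fold higher number from compound 2 to compound 3 (0.00 log units; that floor lies within the scatter), so this change shows no stronger inhibition, and no order between the two can be stated. Measured against the chlorine-bearing chain, the ring gives an at least 11-fold higher number from compound 1 to compound 3 (1.04 log units; beyond the scatter), which leaves compound 1 with the strongest inhibition of the three compounds at this position on the shared core.

Compound 1 differs from compound 2 and compound 3 across the whole group at once, so the separate contributions of the chlorine, the double bond, the triple bond and the ring cannot be told apart from these data. Also open, on these data alone, is how this read-out would respond on the same aromatic nitrogen to a 4-chlorobut-2-yn-1-yl chain, a 4-aminobut-2-yn-1-yl chain or a saturated 4-chlorobutyl chain, each of which would separate these features more cleanly.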